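The compounds below may be only part of what the source reports. "The series", "measured", "known", "first", "only" and "open" are said of these compounds alone.

Compound 3, whose structure is `C=CCn1c(=O)/c(=C\c2ccc(F)c(Br)c2)[nH]c(=O)/c1=C\c1ccccc1OC`, is the starting point here, and in a functional assay on BGC-823 cells (Homo sapiens) for cytotoxicity, read by CCK-8 assay, with a stated time of 72 h (a higher number here means a weaker inhibitor, a lower number a stronger inhibitor), compound 3 is recorded only as "not active" (no number reported), with no number given, so it cannot be placed on the scale alongside its neighbours. Its closest measured relatives are compound 1, with structure `C=CCn1c(=O)/c(=C\c2cccc(Cl)c2)[nH]c(=O)/c1=C\c1ccccc1OC`, which in this assay gives 4600 nM, and compound 2, with structure `C=CCn1c(=O)/c(=C\c2ccccc2Cl)[nH]c(=O)/c1=C\c1ccccc1OC`, which in this assay gives 4600 nM. The only step measured in one place among these compounds, no change at the digits printed from compound 1 to compound 2 (within the scatter), shows that moving the chlorine around the ring left the result unchanged within the scatter.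

Compound 4, with structure `C=CCn1c(=O)/c(=C\c2cccc(C)c2)[nH]c(=O)/c1=C\c1ccccc1OC`, differs from compound 3 as follows: 3-methylphenyl in place of 3-bromo-4-fluorophenyl on a double-bonded chain carbon bound to an aromatic carbon. Among the measured compounds shown here, no measured step covers the exchange of a halogenated ring for a methyl-bearing one, so the change from compound 3 cannot be sized from a direct precedent, and compound 3 itself supplies no number to step from. What remains is the observation that compound 2 and compound 1, which carry a single substituent on that ring, both sit near 4600 nM. On that basis compound 4 is expected to land in the same region of this assay, with an estimated value of 6000 nM and a range from 2000 nM to 20000 nM.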

Compound 4, half-maximal inhibitory concentration: 20400 nM
Estimate against measurement, compound 4: 3.4-fold (0.53 log units) below; the measured number lies above the stated range.
By their numbers in this assay, from the lowest: compounds 1 and 2 (each within the scatter of the next); then compound 4.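

In this assay, among the compounds shown here, methyl in place of chloro on an aromatic carbon of the ring at this double-bonded chain carbon gives a 4.4-fold higher number from compound 1 to compound 4 (0.65 log units; beyond the scatter) and is the first change here to lie beyond the scatter. The exchange of 2-chlorophenyl for 3-methylphenyl gives a 4.4-fold higher number from compound 2 to compound 4 (0.65 log units; beyond the scatter) of the same printed size, so the result at this place depends on which substituent the ring carries, whereas the earlier pair, both bearing chlorine, showed no separation. Nothing available here accounts for this difference between chloro and methyl.

The compounds shown leave open how an amine, a nitrile or a carboxylic acid on this ring would compare with chloro and methyl, and whether the step seen here would recur with either group at another ring carbon. They also leave open how the 3-bromo-4-fluorophenyl of compound 3 relates to the 3-methylphenyl of compound 4, as compound 3 is recorded only as not active and so offers no number to set against the others.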